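Resolving the stereocentre in an oxalamide nitrile series

The source may hold more compounds than are shown below. What is called first, only, known or untested is meant among the compounds shown, and "the series" means these compounds.

Measured so far:
compound 1, `N#Cc1cnn(-c2ccccc2)c1NC(=O)C(=O)Nc1c(C#N)cnn1-c1ccccc1`, 44%
compound 2, `CC(NC(=O)C(=O)Nc1c(C#N)cnn1-c1ccccc1)c1ccccc1`, 50%

The two compounds share a core carrying a nitrile and an oxalamide linker. In a functional assay on the whole organism (strain Wistar albino) for inhibition, with Rattus norvegicus as the target, read by paw edema, in the formalin test, with a stated time of 1 h, at a dose of 20 mg/kg by the oral route (on this read-out higher numbers stand for more inhibition at the one dose given (going by the name of the read-out) and lower numbers for less inhibition), compound 1 gives 44%. In this assay compound 2 gives 50%, the higher of the two numbers, though the gap to compound 1 lies within the scatter, so the two cannot be ordered on this evidence.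

Compound 3, `C[C@@H](NC(=O)C(=O)Nc1c(C#N)cnn1-c1ccccc1)c1ccccc1`, is the next step. It differs from compound 2 only in stereochemistry: the two compounds have the same atoms and bonds; at least one stereo element is drawn with a configuration in one of them and without one in the other: 1 of 1 stereo elements differ; a stereocentre at a saturated chain carbon is drawn without a configuration in compound 2 and R in compound 3. Among the compounds with values here, no step between measured compounds is available, so no size of effect can be drawn from the set. Compound 3 is expected to move little from compound 2, a step of no change at the digits printed from compound 2 to compound 3 (within the scatter) in this assay, with either direction possible. Compound 3 is estimated at 50%, with a range from 30% to 70%.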

Compound 3, a percentage reported as inhibition, in the whole organism at one dose (the size of the read-out at that dose, not a potency): 56%
The estimate for compound 3 lay 6 percentage points below the measured number, within the range that was stated.
By their numbers in this assay, from the lowest: compounds 1, 2 and 3 (each within the scatter of the next, the first and the last beyond it).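

In this assay, within the data shown here, defining the stereocentre at the saturated chain carbon as R gives a number 6 percentage points higher from compound 2 to compound 3 (within the scatter), the first direct reading at this position. With the atoms and bonds unchanged, drawing this carbon as R gives no difference from the undefined form that can be separated from the usual variation in this read-out. This comparison isolates one feature of the drawn structures: the fact that one of compounds 2 and 3 is drawn with a defined configuration and the other without, at the place where they differ

The compounds shown do not reveal how the S configuration at this carbon would read in this assay, so the two configurations cannot yet be compared with each other. They also leave open whether an amine or a longer chain at this stereocentre would give a number separable from those of compound 2 and compound 3.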